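The compounds below may be only part of what the source reports. "The series", "measured", "known", "first", "only" and "open" are said of these compounds alone.

Compound 1 `COc1cccc2c1nc(C)n2-c1ccc(C(=O)NC2CC2)s1`: 4 mL/min/kg
Compound 2 `Cc1nc2c(Cl)cccc2n1-c1ccc(C(=O)NC2CC2)s1`: < 4 mL/min/kg, a limit

In an in vitro ADME assay on microsomes from liver (Homo sapiens) for pharmacokinetics, read by LC-MS (a lower number here means slower removal, a higher number faster removal of the compound), compound 2 reads < 4 mL/min/kg, which is a limit of the assay and not a number. Compound 3 `Cc1nc2c(Br)cccc2n1-c1ccc(C(=O)NC2CC2)s1` differs from it by bromo in place of chloro on an aromatic carbon. For the measured compounds named here, the only measured step, a number no higher from compound 1 to compound 2 (the limit leaves the size open), is a different exchange, and its size stays open. It therefore gives no ground for a shift in either direction. The expected step is a number no lower from compound 2 to compound 3 (the limit leaves the size open), with nothing expected beyond the scatter in this assay. Compound 3 is estimated at 4 mL/min/kg, with an expected range of 3 mL/min/kg to 8 mL/min/kg.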

Compound 3, clearance: 5 mL/min/kg
Compound 3: the middle estimate sits 1.3-fold (0.10 log units) below what was measured; the measured number falls inside the stated range.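

In this assay, bromo on this aromatic carbon gives a number that can be set against methoxy, and the two lie within the scatter of each other: a 1.3-fold higher number from compound 1 to compound 3 (0.10 log units; within the scatter). The exchange of chloro for bromo yields only a floor, an at least 1.2-fold higher number from compound 2 to compound 3 (0.09 log units; that floor lies within the scatter), so it shows no change beyond the scatter and leaves the true size unread. The value of compound 2 is a limit and not a number: the limit of < 4 mL/min/kg in this assay, at which 1 of the 3 values shown sits.

The compounds shown leave open how far compound 2 lies from its limit. They also leave open how an amine or a carboxylic acid on this aromatic carbon would read in this assay.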